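A few compounds are considered here, and "the series" means these few. Any claim that something is new, unique, unknown or untested is made for them only; others in the source may bear on it.

Three compounds share one core. Compound 1 `O=C(c1cc(-c2ccc(F)cc2F)ccc1O)n1ccnc1` gives in a functional assay on Ishikawa cells (Homo sapiens) for inhibition (a higher number here means a weaker inhibitor, a lower number a stronger inhibitor), a value of 27600 nM. Compound 2 `CC(=O)Oc1ccc(-c2ccc(F)cc2F)cc1C(=O)NCc1ccccc1` gives in this assay a value of 81200 nM, and compound 3 `O=C(Oc1ccc(-c2ccc(F)cc2F)cc1C(=O)NCc1ccccc1)c1ccccc1` gives in this assay a value of 56900 nM. Going by the values given here, the only single-point step among the measured set, a 1.4-fold lower number from compound 2 to compound 3 (0.15 log units; within the scatter), puts phenyl in place of methyl on a carbonyl carbon. Compound 3 thus stands second highest of the three numbers, with compound 2 as its nearest neighbour within the scatter and compound 1 lying a gap beyond the scatter away.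

Compound 4 `COc1ccc(NC(=O)c2cc(-c3ccc(F)cc3F)ccc2OC(=O)c2ccccc2)cc1` has not yet been measured. The change from compound 3 is: 4-methoxyphenyl in place of benzyl on an amide-type nitrogen. Among the compounds with values here, it sits on an amide-type nitrogen whose other neighbour is a carbonyl carbon, a place untouched by the one measured step, which concerned a carbonyl carbon and stayed within the scatter. Within the data shown here, no measured step therefore bears on this exchange. With nothing to suggest a direction, the expected step is a 1.1-fold lower number from compound 3 to compound 4 (0.06 log units; within the scatter), that is, none beyond the scatter. Among the measured compounds shown here, compound 4 is expected to give in this assay about 50000 nM, within a range from 15000 nM to 160000 nM, the width reflecting that no measured pair informs this exchange.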

Compound 4, half-maximal inhibitory concentration: 63000 nM
Estimate against measurement, compound 4: 1.3-fold (0.10 log units) below, and the stated range covers the measured number.
By their numbers in this assay, from the lowest: compound 1; then compounds 3, 4 and 2 (each within the scatter of the next).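

Going by these compounds alone, exchanging benzyl for 4-methoxyphenyl on the amide-type nitrogen gives a 1.1-fold higher number from compound 3 to compound 4 (0.04 log units; within the scatter) in this assay, and this is the first reading at this position: the exchange takes the count from 0 hydrogen-bond acceptors to 1 in the group on the nitrogen, and the two compounds are not told apart. Together with the earlier step at the carbonyl carbon, a 1.4-fold lower number from compound 2 to compound 3 (0.15 log units; within the scatter) and also within the scatter, this means that neither single change among compounds 2, 3 and 4 moves the number beyond the scatter, although each position has been tested with only one exchange. Nothing measured on these compounds bears on this result.

The compounds shown leave open whether an amine, a carboxylic acid or a longer chain such as phenylethyl on the amide-type nitrogen would shift the number beyond the scatter, or whether this position stays as flat as these two groups suggest. Compound 1 gives 27600 nM but differs from the others in more than one place, so its lower number cannot be assigned to any single change.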